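The source may report more compounds than this note shows. Statements on the series, on what has been measured and on what is new or still open speak of the compounds shown alone.

Measured compounds in a functional assay on MDA-MB-231 cells (Homo sapiens) for antiproliferative activity, read by CCK-8 assay, with a stated time of 72 h; a lower number here means a stronger inhibitor, a higher number a weaker inhibitor:
- compound 1 `O=C(Nc1cccc(-c2oc3cc(-c4ccc(F)cc4)ccc3c(=O)c2O)c1)c1ccc(F)cc1` gives 16000 nM
- compound 2 `O=C(Nc1cccc(-c2oc3cc(-c4ccc(F)cc4)ccc3c(=O)c2O)c1)c1ccc(Br)cc1` gives 24900 nM
- compound 3 `O=C(Nc1cccc(-c2oc3cc(-c4ccc(F)cc4)ccc3c(=O)c2O)c1)c1cccc(F)c1` gives 2510 nM

Compound 2 stands at the highest number of the three. Its nearest neighbour is compound 1, and the step of a 1.6-fold higher number from compound 1 to compound 2 (0.19 log units; within the scatter) lies within the scatter, so the two cannot be ordered. The gap to compound 3 is a 9.9-fold lower number from compound 2 to compound 3 (1.00 log units; beyond the scatter), a modest lowering; the parallel step a 6.4-fold lower number from compound 1 to compound 3 (0.80 log units; beyond the scatter) points the same way.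

Compound 4 is `Cc1cc(C)cc(C(=O)Nc2cccc(-c3oc4cc(-c5ccc(F)cc5)ccc4c(=O)c3O)c2)c1`. Against compound 2 the change is 3,5-dimethylphenyl in place of 4-bromophenyl on a carbonyl carbon. Among the measured compounds shown here, two measured steps bear on it. The exchange of bromo for fluoro on the same phenyl, a 1.6-fold higher number from compound 1 to compound 2 (0.19 log units; within the scatter), changed nothing beyond the scatter, so the loss of the bromine alone is not expected to move the number. The replacement of the 4-bromophenyl by a 3-fluorophenyl, a 9.9-fold lower number from compound 2 to compound 3 (1.00 log units; beyond the scatter), lowered the number modestly, and the 3,5-dimethylphenyl of compound 4 shares its substitution pattern with the 3-fluorophenyl of compound 3 rather than with the 4-bromophenyl of compound 2. For the measured compounds named here, no measured compound carries methyl groups on this ring, so the size of the step is uncertain.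

A lowering in this assay is therefore expected, of about a 4.2-fold lower number from compound 2 to compound 4 (0.62 log units; beyond the scatter), smaller than the step to compound 3 to allow for the untested methyl groups. For compound 4 the estimate is 6000 nM, with a range from 1500 nM to 25000 nM.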

Compound 4, half-maximal inhibitory concentration: 11900 nM
Estimate against measurement, compound 4: 2.0-fold (0.30 log units) below; low and high end bracket the measured number.
By their numbers in this assay, from the lowest: compound 3; then compounds 4, 1 and 2 (each within the scatter of the next, the first and the last beyond it).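

In this assay, the 3,5-dimethylphenyl on the carbonyl carbon gives a 2.1-fold lower number from compound 2 to compound 4 (0.32 log units; beyond the scatter), a step only just past the scatter, while a 1.3-fold lower number from compound 1 to compound 4 (0.13 log units; within the scatter) leaves compound 4 and compound 1 unordered. The larger step is a 4.7-fold higher number from compound 3 to compound 4 (0.68 log units; beyond the scatter), so among these four compounds the low number of compound 3 stays with the 3-fluorophenyl and does not carry over to the 3,5-dimethylphenyl; a shared substitution pattern alone does not account for it, and compound 4 is the case against that reading. No measurement on hand explains why these aryl groups differ in this assay.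

Still open, going by these compounds, is whether a phenyl carrying a single methyl, a chlorine or a methoxy group on this carbonyl carbon would stay near compound 3 at 2510 nM or fall back towards the others. On these data alone, it is equally open whether an aromatic ring is needed here at all, which a cyclohexyl or a pyridine ring in place of the phenyl would test.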